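This account rests on a few compounds, and the source may have more. Where it says the series, first, only, none or still open, it means among the compounds named here.

Compound 2 `Clc1ccc(/C=C2\CCN=C2c2cccnc2)cc1` stands at > 10000 nM in an assay for displacement of a labelled ligand from Nicotinic acetylcholine receptor alpha8 subunit (Periplaneta americana), read by scintillation counting, with a stated time of 2 h, at 24 degrees C (on this read-out lower numbers stand for stronger inhibition and higher numbers for weaker inhibition), which is a limit of the assay rather than a number. Compound 1 `C(=C1\CCN=C1c1cccnc1)\c1ccccc1` likewise gives > 10000 nM in this assay, again a limit. The only measured step, a step that the two limits leave unreadable from compound 1 to compound 2, is therefore of unreadable size; all that is shown is the limit of > 10000 nM in this assay, at which 2 of the 2 values shown sit. Compound 3 `N#Cc1ccc(/C=C2\CCN=C2c2cccnc2)cc1` differs from compound 2 by cyano in place of chloro on an aromatic carbon. Within the data shown here, no measured step bears on this change, so no direction beyond the scatter can be read. The expected step is a step that the limit leaves unreadable from compound 2 to compound 3. For compound 3 the estimate in this assay is 20000 nM, within 5000 nM to 100000 nM.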

Compound 3, half-maximal inhibitory concentration: > 10000 nM
Compound 3 was reported as a limit; the forecaster's own chance of this, stated with the estimate: 80%; the middle value lies beyond the limit too.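

Compound 3 gives > 10000 nM in this assay, a limit and not a number. No step among compound 1, compound 2 and compound 3 can be read: the limit of > 10000 nM in this assay, at which 3 of the 3 values shown sit.

On these data alone, how hydrogen, chloro and cyano on the aromatic carbon compare in this assay stays open.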